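The compounds below may be only part of what the source reports. "The series", "measured", "known", "first", "only" and "open" are said of these compounds alone.

Measured in an ADME assay on WI-38 cells (Homo sapiens) for cytotoxicity, read by MTT assay, with a stated time of 72 h; on this read-out lower numbers stand for stronger inhibition and higher numbers for weaker inhibition:
- compound 1 `CC(C)c1cccc(NC(=O)CCc2cccc3c2B(O)OC3)c1`: 22000 nM
- compound 2 `O=C(CCc1cccc2c1B(O)OC2)Nc1cccc(-c2cccc(F)c2)c1`: 37000 nM

Among the measured compounds shown here, compound 2 sits within the scatter of compound 1, its only measured neighbour in this assay. Compound 3 `O=C(CCc1cccc2c1B(O)OC2)Nc1cccc(-c2ccc(Cl)cc2)c1` has 4-chlorophenyl in place of 3-fluorophenyl on an aromatic carbon, meta to a large group: 4-chlorophenyl in place of 3-fluorophenyl on an aromatic carbon. For the measured compounds named here, the only measured step, a 1.7-fold higher number from compound 1 to compound 2 (0.23 log units; within the scatter), also exchanges a group on an aromatic carbon and stays small. No change beyond the scatter is therefore expected, and the expected step is a 1.2-fold lower number from compound 2 to compound 3 (0.09 log units; within the scatter). For compound 3 the estimate is 30000 nM, with an expected range of 13000 nM to 65000 nM.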

Compound 3, half-maximal inhibitory concentration: 9800 nM
Beside the measured number, compound 3's estimate is 3.1-fold (0.49 log units) above it; the whole stated range lies above it.
By their numbers in this assay, from the lowest: compound 3; then compounds 1 and 2 (each within the scatter of the next).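

In this assay, the position meta to a large group proves sensitive to the aromatic group it carries: 4-chlorophenyl in place of 3-fluorophenyl gives a 3.8-fold lower number from compound 2 to compound 3 (0.58 log units; beyond the scatter) and 4-chlorophenyl in place of isopropyl gives a 2.2-fold lower number from compound 1 to compound 3 (0.35 log units; beyond the scatter). The first exchange keeps the heavy-atom count and the carbon-only aromatic ring, yet still moves the number beyond the scatter. Nothing available accounts for this shift.

The exchange alters both the halogen and its place on the ring, so the two remain unseparated. A 4-fluorophenyl or 3-chlorophenyl group would separate them, while an aminophenyl or carboxyphenyl group remains an open test of this position.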